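Notes on a 4-bromophenyl swap in the series

The source may hold more compounds than are shown below. What is called first, only, known or untested is meant among the compounds shown, and "the series" means these compounds.

Compound 1 `O=C1C=C(NCc2ccccc2)C(=O)c2c1nc1n2[C@H]2OC[C@@H](O)[C@H]2OC1`: 2670 nM
Compound 2 `O=C1C(Nc2ccccc2F)=CC(=O)c2c1nc1n2[C@H]2OC[C@@H](O)[C@H]2OC1`: 2000 nM

Only these two compounds have been measured so far, both in a functional assay on MGC-803 cells (Homo sapiens) for inhibition, read by sulforhodamine B assay; a higher number here means a weaker inhibitor, a lower number a stronger inhibitor. Compound 2 at 2000 nM lies within the scatter of compound 1 at 2670 nM, so the numbers give no ranking between them.

The next compound is compound 3 `O=C1C(Nc2ccc(Br)cc2)=CC(=O)c2c1nc1n2[C@H]2OC[C@@H](O)[C@H]2OC1`, which keeps the shared core of compound 2 and has not yet been measured. The change is 4-bromophenyl in place of 2-fluorophenyl on an amine nitrogen. Going by the values given here, no measured pair differs in one place only, so the data hold no direct precedent for this swap, and the range has to stay wide. Among the compounds with values here, the only guide is that compound 1 and compound 2 give values close together. No direction is therefore expected beyond the scatter in this assay. The estimated change a 1.1-fold lower number from compound 2 to compound 3 (0.05 log units; within the scatter) is expected to be small. For compound 3 the expected value is 1800 nM, with an estimated range from 600 nM to 5000 nM in this readout.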

Compound 3, half-maximal inhibitory concentration: 2020 nM
For compound 3 the middle estimate is 1.1-fold (0.05 log units) below the measured one; low and high end bracket the measured number.
By their numbers in this assay, from the lowest: compounds 2, 3 and 1 (each within the scatter of the next).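

In this assay, going by these compounds alone, 4-bromophenyl in place of 2-fluorophenyl on an amine nitrogen gives a 1.0-fold higher number from compound 2 to compound 3 (0.00 log units; within the scatter), the first step that differs in one place only. At this position, the 2-fluorophenyl and 4-bromophenyl groups therefore cannot be told apart in this readout, something the earlier pair could not show because compound 1 and compound 2 differ in more than one place. No data are at hand that bear on why these two groups read alike.

The swap alters both the halogen and where it sits on the phenyl ring, so the two compounds shown leave open whether either alteration alone would matter, a question that 4-fluorophenyl or 2-bromophenyl at the same amine nitrogen would address. Also open, from the compounds shown here alone, is how far this flat reading extends beyond halogen-bearing phenyl groups, for instance to a phenyl carrying a carboxylic acid or a methoxy group, or to a morpholine or a longer alkyl chain on that nitrogen.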